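The source may report more compounds than this note shows. Statements on the series, on what has been measured and on what is new or still open speak of the compounds shown alone.

Working notes on the series. For the measured compounds named here, compound 3 `O=C(NCCCOc1cccc(CN2CCCCC2)c1)Nc1cccc(C(F)(F)F)c1` in an assay on isolated protein for inhibition of histamine H2 receptor (Cavia porcellus) (on this read-out lower numbers stand for tighter binding and higher numbers for weaker binding), gives 813 nM, the second highest of the three numbers measured so far. Compound 1 `COc1ccc(N/C(S)=N/CCCOc2cccc(CN3CCCCC3)c2)cc1` gives 4370 nM in this assay, and compound 2 `O=C(NCCCOc1cccc(CN2CCCCC2)c1)Nc1ccccc1` gives 126 nM. Going by the values given here, the one step between measured compounds that differ in a single place runs a 6.5-fold higher number from compound 2 to compound 3 (0.81 log units; beyond the scatter), a modest move between two aromatic substituents. Compound 1 differs in more than one place and stands higher than both. The next compound is compound 4 `CC(C)CNC(=O)NCCCOc1cccc(CN2CCCCC2)c1`, not yet measured; relative to compound 3 the change is isobutyl in place of 3-(trifluoromethyl)phenyl on an amide-type nitrogen. Among the compounds with values here, no measured step bears directly on exchanging an aromatic group for an alkyl chain on that amide-type nitrogen, so only the size of the step of a 6.5-fold higher number from compound 2 to compound 3 (0.81 log units; beyond the scatter) gives a sense of how much this position moves the numbers. The expected step in this assay is a 2.0-fold lower number from compound 3 to compound 4 (0.31 log units; beyond the scatter), with the direction uncertain. For compound 4 the estimate in this assay is 400 nM, with a range from 100 nM to 1600 nM.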

Compound 4, dissociation constant: 170 nM
Estimate against measurement, compound 4: 2.4-fold (0.37 log units) above; the range from low to high includes it.
By their numbers in this assay, from the lowest: compounds 2 and 4 (each within the scatter of the next); then compound 3; then compound 1.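

Within this assay, the aromatic ring on the amide-type nitrogen proves dispensable: isobutyl in place of 3-(trifluoromethyl)phenyl gives a 4.8-fold lower number from compound 3 to compound 4 (0.68 log units; beyond the scatter) and isobutyl in place of phenyl gives a 1.3-fold higher number from compound 2 to compound 4 (0.13 log units; within the scatter) so plain phenyl and isobutyl cannot be told apart at this position. Among these three compounds, the higher number of compound 3 therefore goes with the trifluoromethyl-bearing group and not with the presence of an aromatic ring as such. Nothing on hand gives a reason for this behaviour at the amide-type nitrogen.

Going by these compounds, it remains open whether a longer chain, a cyclohexyl ring or a chain ending in an amine on that nitrogen would stay in the range of compound 2 and compound 4. On these data alone, it is also open whether a chloro group on the phenyl ring would raise the number as trifluoromethyl does.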